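This account rests on a few compounds, and the source may have more. Where it says the series, first, only, none or still open, it means among the compounds named here.

Measured compounds and their values:
compound 1, `CCCCCCOc1ccc(-n2cnnc2CCC)cc1`, gives 5.7 mg/kg in a functional assay on the whole organism (strain C57B/6) with Mus musculus as the target, in the maximal electroshock model; on this read-out higher numbers stand for an effect only at larger amounts of compound and lower numbers for an effect already at smaller amounts.
compound 3, `CCCCCCOc1ccc(-n2cnnc2-c2ccccc2)cc1`, gives 19 mg/kg.
compound 2, `CCCCCCCCCc1nncn1-c1ccc(OCCCCCC)cc1`, gives no number but only a limit of the assay, > 40 mg/kg.

Among the two real numbers compound 1 stands lowest, meaning it acts at the smallest dose; the nearest is compound 3, reached by a 3.3-fold higher number from compound 1 to compound 3 (0.52 log units; beyond the scatter). Compound 2 sits at the limit of > 40 mg/kg in this assay, at which 1 of the 3 values shown sits, and an at least 7.0-fold higher number from compound 1 to compound 2 (0.84 log units; beyond the scatter) shows that hexyl in place of hydrogen on the chain pushed the dose past what the assay reports.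

Compound 4, `CCCCCCOc1ccc(-n2cnnc2Cc2ccccc2)cc1`, differs from compound 1 by phenyl in place of ethyl on a saturated chain carbon bound to an aromatic carbon. Read one bond further out, the change is propyl to benzyl, so it sits between compound 1 and compound 3. The step that bears on it directly is a 3.3-fold higher number from compound 1 to compound 3 (0.52 log units; beyond the scatter), a modest rise. A smaller rise, probably beyond the scatter but below that of compound 3, is expected for compound 4.

Compound 4 is therefore estimated at 12 mg/kg, with a range from 5.5 mg/kg to 28 mg/kg. For compound 4 this expectation amounts to a 2.1-fold higher number from compound 1 to compound 4 (0.32 log units; beyond the scatter).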

Compound 4, dose for half-maximal effect: 19 mg/kg
Estimate against measurement, compound 4: 1.6-fold (0.20 log units) below; low and high end bracket the measured number.
By their numbers in this assay, from the lowest: compound 1; then compounds 3 and 4 (each within the scatter of the next). At a limit, above all of these: compound 2.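

In this assay, a phenyl ring gives the same outcome whether it replaces the propyl of compound 1 directly or as benzyl, which compound 4 shows as a modest rise in dose (a 3.3-fold higher number from compound 1 to compound 4 (0.52 log units; beyond the scatter)). Benzyl in place of phenyl makes no difference that can be read (no change at the digits printed from compound 3 to compound 4 (within the scatter)), so among these compounds, adding the chain carbon does not bring back the lower dose of compound 1. Compound 2 gives no number, so the comparison with its nonyl analogue (an at least 2.1-fold lower number from compound 2 to compound 4 (0.32 log units; beyond the scatter)) sets only a minimum gap, and its value is a limit: the limit of > 40 mg/kg in this assay, at which 1 of the 4 values shown sits.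

From the compounds shown here alone, whether methyl on the same carbon of the core would lower the dose further stays open. So does whether an amine or a carboxylic acid on the phenyl of compound 4 would shift it.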